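Capping the Phenol: Hydroxy to Methoxy on the Anilide

The source may report more compounds than this note shows. Statements on the series, on what has been measured and on what is new or still open speak of the compounds shown alone.

Compound 3 `O=C(Nc1ccc(O)cc1)C1CCc2ccccc2N1` carries a hydroxy on the anilide ring of the shared core. In a functional assay on MDA-MB-231 cells (Homo sapiens) for cytotoxicity, read by sulforhodamine B assay, with a stated time of 72 h (a higher number here means a weaker inhibitor of growth, a lower number a stronger inhibitor of growth), compound 3 gives only a limit of the assay, > 100000 nM. Its trifluoromethyl counterpart, compound 2 `O=C(Nc1ccc(C(F)(F)F)cc1)C1CCc2ccccc2N1`, gives 24200 nM in this assay. Going by the values given here, the step of an at least 4.1-fold higher number from compound 2 to compound 3 (0.61 log units; beyond the scatter) is therefore the one measured change on this ring, and it points to the hydroxy as the weaker choice, bounded by the limit of > 100000 nM in this assay, at which 1 of the 3 values shown sits. Compound 1 `CC(=O)N1c2ccccc2CCC1C(=O)Nc1ccccc1O`, a different variant of the core, gives 89600 nM in this assay, which places it among the weak inhibitors as well.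

Compound 4 `COc1ccc(NC(=O)C2CCc3ccccc3N2)cc1` differs from compound 3 by methyl in place of hydrogen on an oxygen on an aromatic ring. Among the compounds with values here, no measured pair here covers this methylation of the phenol; the only related evidence is the hydroxy-for-trifluoromethyl step, which showed that the hydroxy analogue falls at the limit. The expected step of an at least 1.2-fold lower number from compound 3 to compound 4 (0.09 log units; that floor lies within the scatter) is thus a small move toward lower numbers, not clearly beyond the scatter, since the methoxy removes the hydroxy but does not restore the trifluoromethyl. Compound 4 is accordingly expected to give about 80000 nM in this assay, with a range from 30000 nM to 200000 nM, and it may again reach only a limit.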

Compound 4, concentration for 50% growth inhibition: 51400 nM
Beside the measured number, compound 4's estimate is 1.6-fold (0.19 log units) above it, and the stated range covers the measured number.
By their numbers in this assay, from the lowest: compound 2; then compounds 4 and 1 (each within the scatter of the next). At a limit, above all of these: compound 3.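

Going by these compounds alone, the methylation gives the first number for a group bound through oxygen on this anilide ring, since the hydroxy of compound 3 offered only a limit. In this assay the change reads as an at least 1.9-fold lower number from compound 3 to compound 4 (0.28 log units; that floor lies within the scatter) and so cannot by itself be called a gain, although compound 4 does come inside the measurable range. The new comparison with the trifluoromethyl is firmer, with a 2.1-fold higher number from compound 2 to compound 4 (0.33 log units; beyond the scatter) showing that methoxy in this place remains a modest step behind trifluoromethyl, and the reading against the hydroxy stays only a floor for one reason, that compound 3 sits at a limit: the limit of > 100000 nM in this assay, at which 1 of the 4 values shown sits.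

What the compounds shown leave open is whether any other group on an aromatic carbon here, such as an amine, a nitrile, a carboxylic acid or a longer chain on the oxygen such as ethoxy, would match or pass the trifluoromethyl of compound 2. They also leave open what an acetyl on the ring nitrogen does alone, as compound 1 differs from the others in more than one place.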